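Methoxy on the benzoyl ring of compound 1

The source may report more compounds than this note shows. Statements on the series, on what has been measured and on what is new or still open speak of the compounds shown alone.

Measured compounds:
compound 1 `Cc1nc(NC(=O)c2ccccc2)c2nn(-c3ccccc3)cc2n1`: 30%
compound 2 `COc1ccc(-n2cc3nc(Cc4ccccc4)nc(N)c3n2)cc1`: 40%
compound 3 `Cc1nc(N(C(=O)c2ccccc2)C(=O)c2ccccc2)c2nn(-c3ccccc3)cc2n1`: 6%

In an assay on CHO cells for displacement of a labelled ligand from adenosine receptor A1 (Homo sapiens), read by scintillation counting, with a stated time of 120 min, tested at 1 uM (on this read-out higher numbers stand for more inhibition at the one concentration tested (going by the name of the read-out) and lower numbers for less inhibition), compound 1 gives 30%. It stands second highest of the three numbers; its nearest neighbour is compound 2, whose value is within the scatter of it, and its furthest is compound 3, which lies beyond the scatter. Among the compounds with values here, the one step measured from compound 1 is a number 24 percentage points lower from compound 1 to compound 3 (beyond the scatter), a modest loss that follows from benzoyl in place of hydrogen on an amide-type nitrogen.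

Compound 4 `COc1ccc(C(=O)Nc2nc(C)nc3cn(-c4ccccc4)nc23)cc1` differs from compound 1 in another place: methoxy in place of hydrogen on an aromatic carbon. Within the data shown here, no measured step bears on this change. Among the measured compounds shown here, compound 2 carries a methoxyphenyl group on its core, but the rest of compound 2 differs from compound 1 in more than one place, so its value and that of compound 1, which lie within the scatter of each other, give no step to lean on. The step from compound 1 to compound 3 concerns the amide nitrogen and says nothing about the ring.

Compound 4 is therefore expected to remain near compound 1, with an estimated step of no change at the digits printed from compound 1 to compound 4 (within the scatter), not beyond the scatter. The estimate for compound 4 in this assay is 30%, in a range from 12% to 50%.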

Compound 4, a percentage reported as inhibition, at one concentration (the size of the read-out at that concentration, not a potency): 4%
Beside the measured number, compound 4's estimate is 26 percentage points above it, outside the stated range (below it).
By their numbers in this assay, from the lowest: compounds 4 and 3 (each within the scatter of the next); then compounds 1 and 2 (each within the scatter of the next).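

In this assay, a change on the benzoyl ring of compound 1 lowers the number: methoxy on an aromatic carbon, para to a large group, gives a number 26 percentage points lower from compound 1 to compound 4 (beyond the scatter). Within the data shown here, until this result, the only step from compound 1 concerned the amide nitrogen, so the earlier compounds said nothing about this ring; it is now clear that the ring carbon also matters, and that a group of only 2 heavy atoms is enough for a step beyond the scatter. Nothing shown here accounts for the loss.

The compounds shown leave open whether the loss belongs to methoxy itself or would follow from any group at this carbon, as a fluorine atom, a hydroxyl or a methyl would test. They also leave open whether methoxy on another carbon of the same ring would give the same result, and whether a longer chain such as ethoxy or an amine at this carbon would lower the number further or restore it.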